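Pyridin-4-yl in place of pyridin-3-yl: cytotoxicity notes

This account rests on a few compounds, and the source may have more. Where it says the series, first, only, none or still open, it means among the compounds named here.

Values in an ADME assay on MT4 cells (Homo sapiens) for cytotoxicity, read by XTT assay, with a stated time of 5 days (on this read-out lower numbers stand for higher toxicity in this test and higher numbers for lower toxicity in this test), for the measured compounds:
Compound 1 `COC(=O)N[C@H](C(=O)NN(CC[C@@](O)(Cc1ccccc1)C(=O)N[C@H]1c2ccccc2C[C@H]1O)Cc1ccc(-c2ccccc2)cc1)C(C)(C)C` gives > 10000 nM as a limit
Compound 2 `COC(=O)N[C@H](C(=O)NN(CC[C@@](O)(Cc1ccccc1)C(=O)N[C@H]1c2ccccc2C[C@H]1O)Cc1ccc(-c2ccccn2)cc1)C(C)(C)C` gives > 10000 nM as a limit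
Compound 3 `COC(=O)N[C@H](C(=O)NN(CC[C@@](O)(Cc1ccccc1)C(=O)N[C@H]1c2ccccc2C[C@H]1O)Cc1ccc(-c2cccnc2)cc1)C(C)(C)C` gives 4900 nM as a measured number

Going by the values given here, compound 3 stands alone here, since 4900 nM is the only true number in the set. The other two readings are limits. Compound 4 `COC(=O)N[C@H](C(=O)NN(CC[C@@](O)(Cc1ccccc1)C(=O)N[C@H]1c2ccccc2C[C@H]1O)Cc1ccc(-c2ccncc2)cc1)C(C)(C)C` differs from compound 3 in one place: pyridin-4-yl in place of pyridin-3-yl on an aromatic carbon and so keeps the same atoms, joined differently.

The steps bearing on this change are an at least 2.0-fold lower number from compound 1 to compound 3 (0.30 log units; that floor lies within the scatter) and an at least 2.0-fold lower number from compound 2 to compound 3 (0.30 log units; that floor lies within the scatter) and both come with no exact size. The third step is a step that the two limits leave unreadable from compound 1 to compound 2 and adds no size either. Among the compounds with values here, all of them are bounded by the limit of > 10000 nM in this assay, at which 2 of the 3 values shown sit, and that leaves no measured step between two numbers.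

In this assay no step beyond the scatter is therefore expected, with only a slight lean toward a higher number. The expected change is a 1.4-fold higher number from compound 3 to compound 4 (0.15 log units; within the scatter) and a reading at the limit would not be a surprise. For compound 4 the estimate is 7000 nM with an expected range from 3000 nM to 20000 nM here.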

Compound 4, half-maximal cytotoxic concentration: > 10000 nM
Compound 4 was reported as a limit (the forecaster's own chance of this, stated with the estimate: 45%); at least 1.4-fold (0.15 log units) between middle value and limit.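

In this assay, pyridin-4-yl in place of pyridin-3-yl gives an at least 2.0-fold higher number from compound 3 to compound 4 (0.30 log units; that floor lies within the scatter), so moving the ring nitrogen on this aromatic carbon's substituent has not yet been shown to matter beyond the scatter. Compound 4 gives > 10000 nM, which is a limit of the assay. The steps among compounds 1, 2 and 4 cannot be read, so phenyl, pyridin-2-yl and pyridin-4-yl cannot be ordered, and compound 3 remains the only compound with a measured number, in a set that is otherwise held at the ceiling: the limit of > 10000 nM in this assay, at which 3 of the 4 values shown sit.

Going by these compounds, the true size of the step from pyridin-3-yl to pyridin-4-yl remains open. Also open, on these data alone, is whether a carboxylic acid or an aminomethyl group on this ring would give a measured number in this assay.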